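This account rests on a few compounds, and the source may have more. Where it says the series, first, only, none or still open, it means among the compounds named here.

- compound 1 `COc1cccc(/C=N/N=C2\C[C@@H](c3ccc(O)cc3)Oc3cc(OC)cc(O)c32)c1`: >= 11300 nM
- compound 2 `O=C(Cc1c[nH]c2ccccc12)N/N=C1\C[C@@H](c2ccc(O)cc2)Oc2cc(O)cc(O)c21`: >= 11300 nM

In a functional assay on L5178Y cells (Mus musculus) for inhibition, read by MTT assay, with a stated time of 24 h (a higher number here means a weaker inhibitor, a lower number a stronger inhibitor), compound 1 gives >= 11300 nM, which is a limit and not a number. Compound 2 gives >= 11300 nM, again a limit. Within the data shown here, compound 1 therefore stands at the limit of >= 11300 nM in this assay, at which 2 of the 2 values shown sit, and no measured step is available.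

Compound 3 `COc1cc(O)c2c(c1)O[C@H](c1ccc(O)cc1)C/C2=N\NC(=O)c1ccc(N)cc1` keeps the core of compound 1 and carries this change: a group of 10 heavy atoms (7 carbon, 2 nitrogen, 1 oxygen; one six-membered aromatic ring of carbon only) in place of a group of 10 heavy atoms (8 carbon, 1 nitrogen, 1 oxygen; one six-membered aromatic ring of carbon only), on a double-bonded nitrogen. No step beyond the scatter is expected in this assay, and no direction can be favoured, so the estimate is a step that the limit leaves unreadable from compound 1 to compound 3. For compound 3 the expected value is 12000 nM, with an estimated range of 4000 nM to 30000 nM.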

Compound 3, half-maximal inhibitory concentration: >= 11300 nM
Compound 3 was reported as a limit; the forecaster's own chance of this, stated with the estimate: 65%; the middle value is on the limit's open side.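

Compound 1 and compound 3 both stand at a limit, so no step between them can be read: the limit of >= 11300 nM in this assay, at which 3 of the 3 values shown sit.

Compound 1, compound 2 and compound 3 leave open how strongly each inhibits, and whether the ((4-aminophenyl)carbonyl)amino group changes that.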